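Trimethoxyphenyl amide: a methoxy added to compound 3

A few compounds are considered here, and "the series" means these few. Any claim that something is new, unique, unknown or untested is made for them only; others in the source may bear on it.

Of the compounds shown here, three sharing an amide-linked benzylic core have been measured in a functional assay on HCC78 cells (Homo sapiens) for antiproliferative activity, read by MTT assay, with a stated time of 48 h; a higher number here means a weaker inhibitor, a lower number a stronger inhibitor. Compound 1 `Cc1cnc(Nc2ncccc2OC(C)c2cccc(C(=O)NCc3ccc(F)c(Cl)c3)c2)s1` gives 34700 nM. Compound 2 `COc1cccc(CNC(=O)c2cccc(C(C)Oc3ccnc(Nc4cnn(C)c4)c3)c2)c1` gives 64400 nM. Compound 3 `COc1ccc(CNC(=O)c2cccc(C(C)Oc3ccnc(Nc4cnn(C)c4)c3)c2)cc1OC` gives 76600 nM, which is the highest of the three numbers; compound 1 sits lower than compound 3 by a gap beyond the scatter, whereas the number of compound 2 lies within the scatter of that of compound 3. The only single-point step among these three is a 1.2-fold higher number from compound 2 to compound 3 (0.08 log units; within the scatter), a change that did not move the read-out beyond the scatter.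

Compound 4 `COc1cc(CNC(=O)c2cccc(C(C)Oc3ccnc(Nc4cnn(C)c4)c3)c2)cc(OC)c1OC` extends this series by one more group: methoxy in place of hydrogen on an aromatic carbon. Going by the values given here, the step that bears on it most directly is the one from compound 2 to compound 3, where the same kind of addition, a methoxy for a hydrogen on the same six-membered ring, left the value essentially unchanged. On that basis a step of similar size is expected from compound 3 to compound 4, namely a 1.2-fold higher number from compound 3 to compound 4 (0.07 log units; within the scatter), with no shift beyond the scatter in either direction. Compound 4 is therefore estimated at 90000 nM, with a range from 45000 nM to 180000 nM.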

Compound 4, half-maximal inhibitory concentration: 73900 nM
Compound 4: the middle estimate sits 1.2-fold (0.09 log units) above what was measured; measured number inside the range.
By their numbers in this assay, from the lowest: compounds 1, 2, 4 and 3 (each within the scatter of the next, the first and the last beyond it).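

In this assay the methoxy that enters here, ortho to a methoxy group and meta to a large group, gives a 1.0-fold lower number from compound 3 to compound 4 (0.02 log units; within the scatter) and so turns the 3,4-dimethoxyphenyl into the 3,4,5-trimethoxyphenyl without any shift that stands out from the scatter. The earlier compounds shown here showed only a single such addition, whereas the full change of 3,4,5-trimethoxyphenyl in place of 3-methoxyphenyl, which gives a 1.1-fold higher number from compound 2 to compound 4 (0.06 log units; within the scatter) and spans two added methoxy groups, shows that they do not add up to a shift beyond the scatter either. Nothing at hand accounts for this flat response.

The compounds shown leave open whether a group other than methoxy on this ring, such as a hydroxyl, an amine or a carboxylic acid, would move the number beyond the scatter, as all three members of this set carry only methoxy groups there. Compound 1 at 34700 nM differs from compound 4 in more than one place, so it cannot settle that question.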